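Cyclopentyl for Isopropyl on a Fluorinated Benzoic Acid

The compounds below may be only part of what the source reports. "The series", "measured", "known", "first", "only" and "open" are said of these compounds alone.

Compound 1 `Cc1c(OCCCCOc2cccc(C(=O)O)c2)ccc(C(=O)CC2CCCC2)c1O` in an assay on HEK293 cells for positive allosteric modulation of metabotropic glutamate receptor 3 (Rattus norvegicus), read by thallium flux, with a stated time of 2.5 min (on this read-out lower numbers stand for smaller maximal responses and higher numbers for larger maximal responses), gives 92.9%.
Compound 2 `Cc1c(OCCCCOc2ccc(F)c(C(=O)O)c2)ccc(C(=O)CC(C)C)c1O` in this assay gives 81.7%.

Compound 2 stands lowest of the two numbers; its nearest neighbour, compound 1, sits higher by a gap beyond the usual scatter. Compound 3 `Cc1c(OCCCCOc2ccc(F)c(C(=O)O)c2)ccc(C(=O)CC2CCCC2)c1O` differs from compound 2 by cyclopentyl in place of isopropyl on a saturated chain carbon bound to a carbonyl carbon. For the measured compounds named here, no measured pair differs in this one place alone, so the size of the step is not known from the data. Because compound 1 carries the cyclopentyl and gives 92.9%, an upward step of modest size is expected. For compound 3 the expected step is a number 7.3 percentage points higher from compound 2 to compound 3 (within the scatter). Compound 3 is estimated at 89%, within a range from 76% to 100%.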

Compound 3, largest response reached (reported as percent of maximum), in percent of the reference or control that the assay uses: 98.4%
Estimate against measurement, compound 3: 9.4 percentage points below; the measured number falls inside the stated range.
By their numbers in this assay, from the lowest: compound 2; then compounds 1 and 3 (each within the scatter of the next).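

In this assay, cyclopentyl in place of isopropyl on a saturated chain carbon bound to a carbonyl carbon now has a size of its own, reading a number 16.7 percentage points higher from compound 2 to compound 3 (beyond the scatter) on the fluorinated benzoic acid. With cyclopentyl in place, fluoro in place of hydrogen on an aromatic carbon reads a number 5.5 percentage points higher from compound 1 to compound 3 (within the scatter) and so is not resolved from the scatter. Nothing measured here gives a reason for either step.

From the compounds shown here alone, how cyclohexyl or a longer chain would fare at this position remains open, as does chloro in place of the fluoro. Whether the cyclopentyl step holds on the benzoic acid without fluoro also cannot be read from these compounds.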